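Chain variation at the aromatic oxygen: compound 3 pending

The source may report more compounds than this note shows. Statements on the series, on what has been measured and on what is new or still open speak of the compounds shown alone.

Measured in a functional assay on mitochondria (Cricetulus griseus) for inhibition of Monoamine oxidase (Homo sapiens), tested at 0.3 uM; on this read-out higher numbers stand for a stronger effect at the one concentration tested and lower numbers for a weaker effect:
compound 1 `O=c1c(-c2ccc(O)cc2)coc2cc(OCCCCCCBr)ccc12`: 47.2%
compound 2 `C=CCOc1ccc2c(=O)c(-c3ccc(O)cc3)coc2c1`: 37.9%

Compound 1 and compound 2 differ in one place, and the step of a number 9.3 percentage points lower from compound 1 to compound 2 (within the scatter) is within the scatter, so the two numbers cannot be told apart; compound 2 simply stands at one of the two numbers in this assay, the other being compound 1.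

Compound 3 `O=c1c(-c2ccc(O)cc2)coc2cc(OCC(O)CO)ccc12` differs from compound 2 by 1,2-dihydroxyethyl in place of vinyl on a saturated chain carbon bound to an oxygen on an aromatic ring. Going by the values given here, the one measured step that bears on this change is the replacement at the same place, from compound 1 to compound 2, which stayed within the scatter. Nothing measured here points to a step beyond the scatter for the next change at this place, so compound 3 is expected to sit close to compound 2, with an estimated step of a number 2.1 percentage points higher from compound 2 to compound 3 (within the scatter). For compound 3 the estimate in this assay is 40%, expected to fall between 25% and 55%.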

Compound 3, a percentage reported as inhibition, at one concentration (the size of the read-out at that concentration, not a potency): 33.3%
Compound 3: middle estimate off by 6.7 percentage points, on the high side; measured number inside the range.
By their numbers in this assay, from the lowest: compounds 3, 2 and 1 (each within the scatter of the next, the first and the last beyond it).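

At the saturated chain carbon bound to an oxygen on an aromatic ring, the series now shows its first step beyond the scatter in this assay: 1,2-dihydroxyethyl in place of 5-bromopentyl gives a number 13.9 percentage points lower from compound 1 to compound 3 (beyond the scatter). By contrast, 1,2-dihydroxyethyl in place of vinyl gives a number 4.6 percentage points lower from compound 2 to compound 3 (within the scatter), so allyloxy and 2,3-dihydroxypropoxy cannot be told apart at this place, and only the two ends of this short set separate. No supporting evidence accompanies these steps.

As far as these compounds go, it remains open whether the separation depends on the length of the chain or on its terminal bromine, which an unsubstituted alkyl chain or a longer bromoalkyl chain would test. From the compounds shown here alone, how an amine or a carboxylic acid at the chain end would read at this place is also open.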